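The source may hold more compounds than are shown below. What is called first, only, known or untested is meant among the compounds shown, and "the series" means these compounds.

Compound 1, `C#CCO/N=C/c1c(-c2ccc(C)cc2)nc2c(C)cccn12`: 40 mg/kg
Compound 2, `COc1ccc(Cn2cc(CO/N=C/c3c(-c4ccccc4)nc4c(C)cccn34)nn2)cc1`: 40 mg/kg

Both values come from a functional assay on the whole organism (strain NMRI) with Mus musculus as the target, in the maximal electroshock model, with a stated time of 4 h; on this read-out lower numbers stand for an effect already at smaller amounts and higher numbers for an effect only at larger amounts of compound. On this read-out compound 2 stands level with compound 1 at the digits shown; the gap between the two lies within the usual scatter of repeated measurements, so nothing separates them.

Compound 3, `COc1ccc(Cn2cc(CO/N=C/c3c(-c4ccc(C)cc4)nc4c(C)cccn34)nn2)cc1`, has not yet been measured. It differs from compound 2 in one place: methyl in place of hydrogen on an aromatic carbon.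

Among the measured compounds shown here, no measured pair isolates exactly this change. What the data do offer is that compound 1 already carries the methyl group on its aromatic ring, with a different side chain on the oxime, and that its value in this assay sits level with that of compound 2. On that basis the expected step in this assay is none beyond the scatter, no change at the digits printed from compound 2 to compound 3 (within the scatter). Compound 3 is therefore estimated at 40 mg/kg, with a likely range from 20 mg/kg to 80 mg/kg.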

Compound 3, minimum effective dose: 100 mg/kg
Compound 3: the middle estimate sits 2.5-fold (0.40 log units) below what was measured, and the stated range ends below it.
By their numbers in this assay, from the lowest: compounds 1 and 2 (each within the scatter of the next); then compound 3.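

In this assay, among the compounds shown here, the change from phenyl to 4-methylphenyl can be read on its own for the first time, and it gives a 2.5-fold higher number from compound 2 to compound 3 (0.40 log units; beyond the scatter). A higher number here means that a larger dose is needed, so with the side chain of compound 2 in place this position does not tolerate the methyl without a cost. The methyl alone does not set the value: compound 1 carries the same 4-methylphenyl with a different side chain and gives 40 mg/kg while compound 3 gives 100 mg/kg on the same read-out.

Going by these compounds, it remains open whether a chlorine atom or an ethyl group at this position would give a similar step, or whether the methyl would cost anything with the side chain of compound 1. Nothing measured here explains why the number rises.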